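The source may hold more compounds than are shown below. What is called first, only, known or untested is meant among the compounds shown, and "the series" means these compounds.

Compound 1 `CN(C(=O)CNC(=O)CN)c1ccc([N+](=O)[O-])cc1C(=O)c1ccccc1Cl` and compound 2 `CN(C(=O)CNC(=O)CN)c1ccc([N+](=O)[O-])cc1C(=O)c1ccccc1` share one core, while compound 3 `CN(C(=O)CNC(=O)c1ccccc1)c1ccc(Cl)cc1C(=O)c1ccccc1Cl` and compound 4 `CN(C(=O)CNC(=O)c1ccccc1)c1ccc(Cl)cc1C(=O)c1ccccc1` share another; the difference between the two cores is not broken down here. In a functional assay on the whole organism with Mus musculus as the target, in the rotarod test (on this read-out lower numbers stand for an effect already at smaller amounts and higher numbers for an effect only at larger amounts of compound), compound 1 gives 10 mg/kg. In the same assay compound 2 gives 2.94 mg/kg. The structural change that separates them is hydrogen in place of chloro on an aromatic carbon, and it brought a 3.4-fold lower number from compound 1 to compound 2 (0.53 log units; beyond the scatter). For compound 3 this assay reports only a limit, > 100 mg/kg, and not a number. From the compounds shown here alone, that is so because of the limit of > 100 mg/kg in this assay, at which 1 of the 3 values shown sits, so how far compound 3 lies beyond that edge is unknown. Among the measured compounds shown here, from compound 3 to compound 4 the change is hydrogen in place of chloro on an aromatic carbon, the same change as the one seen between compound 1 and compound 2, at the same kind of place.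

What can be expected for compound 4 therefore rests on two things: the size of the earlier step, given by a 3.4-fold lower number from compound 1 to compound 2 (0.53 log units; beyond the scatter), and the starting point, which for compound 3 is only an edge rather than a value. The step expected from compound 3 to compound 4 is estimated as an at least 1.6-fold lower number from compound 3 to compound 4 (0.22 log units; that floor lies within the scatter). With that, compound 4 is expected to give about 60 mg/kg in this assay, and the estimate is held to lie between 20 mg/kg and 200 mg/kg, with a real chance that the assay again reports only a limit.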

Compound 4, dose for half-maximal effect: > 100 mg/kg
Compound 4: a limit, no number (the forecaster's own chance of this, stated with the estimate: 50%); middle value at least 1.6-fold (0.22 log units) away from the limit.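

Compound 3 and compound 4 both end at the same limit of the test and not at a number, so no size can be read for the step between them: the limit of > 100 mg/kg in this assay, at which 2 of the 4 values shown sit.

The compounds shown leave open whether going from 2-chlorophenyl to phenyl changes anything in this assay on the core of compound 3, as it does on the core of compound 1.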